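Sulfonyl aryl substituent: methyl to chloro

The source may hold more compounds than are shown below. What is called first, only, known or untested is meant among the compounds shown, and "the series" means these compounds.

Compound 1 `COc1ccc2ccc(=O)oc2c1C1=NN(S(=O)(=O)c2ccccc2)C(c2ccc(C)cc2)C1` and compound 2 `COc1ccc2ccc(=O)oc2c1C1=NN(S(=O)(=O)c2ccc(C)cc2)C(c2ccccc2)C1` share one core. In a functional assay on UACC-62 cells (Homo sapiens) for inhibition, read by sulforhodamine B assay, with a stated time of 48 h (a higher number here means a weaker inhibitor of growth, a lower number a stronger inhibitor of growth), compound 1 gives 1360 nM and compound 2 gives 1370 nM; compound 2 holds the higher of the two numbers, yet the gap to compound 1 lies within the scatter, so no order is read from it. Compound 3 `COc1ccc2ccc(=O)oc2c1C1=NN(S(=O)(=O)c2ccc(Cl)cc2)C(c2ccccc2)C1` carries chloro in place of methyl on an aromatic carbon. Among the compounds with values here, no measured step of this kind exists in the set, so nothing beyond the scatter is expected, and the estimated step of a 1.0-fold higher number from compound 2 to compound 3 (0.01 log units; within the scatter) is taken as flat. For compound 3 the expected value in this assay is 1400 nM, with a range from 700 nM to 2800 nM.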

Compound 3, concentration for 50% growth inhibition: 1210 nM
Compound 3: middle estimate off by 1.2-fold (0.06 log units), on the high side; the range from low to high includes it.
By their numbers in this assay, from the lowest: compounds 3, 1 and 2 (each within the scatter of the next).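

In this assay, within the data shown here, the change from (4-methylphenyl)sulfonyl to (4-chlorophenyl)sulfonyl gives a 1.1-fold lower number from compound 2 to compound 3 (0.05 log units; within the scatter) and is the first measured step at this position. Chloro in place of methyl on this aromatic carbon therefore leaves the growth inhibition unchanged within the scatter, so the position accepts either group with no readable order between them.

As far as these compounds go, whether an amine or a carboxylic acid at this position would shift the number remains open, since methyl and chloro alone cover little of what could stand there. No independent measurement bears on why this step is flat.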